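Shortening a Side Chain: From Compound 2 to Compound 3

A few compounds are considered here, and "the series" means these few. Any claim that something is new, unique, unknown or untested is made for them only; others in the source may bear on it.

Of the compounds shown here, two have been measured in an assay on THP-1 cells for displacement of a labelled ligand from C-C chemokine receptor type 1 (Homo sapiens); on this read-out lower numbers stand for stronger inhibition and higher numbers for weaker inhibition. Compound 1 `CC[C@@H](NC(=O)CC(C)C)C(=O)N1CCC(c2ccc(Cl)cc2)CC1` gives 152 nM in this assay, and compound 2 `CC[C@@H](C)[C@@H](NC(=O)CCc1ccccc1)C(=O)N1CCC(c2ccc(Cl)cc2)CC1` gives 66 nM. Compound 2 stands at the lower of the two numbers, and compound 1, its nearest neighbour, lies beyond the scatter above it. Compound 3 `CC[C@@H](NC(=O)CCc1ccccc1)C(=O)N1CCC(c2ccc(Cl)cc2)CC1` has not yet been measured. It differs from compound 2 in one place: hydrogen in place of ethyl on a saturated chain carbon bound to two saturated chain carbons. Among the measured compounds shown here, no measured pair shows this single change, so its effect can only be expected rather than read off. Compound 1 also carries the ethyl side chain, under a different acyl group, and its 152 nM is the weaker of the two numbers, which leans the expectation toward a loss. Compound 3 is therefore estimated at 150 nM, within a range from 60 nM to 400 nM. The expected step of a 2.3-fold higher number from compound 2 to compound 3 (0.36 log units; beyond the scatter) points toward weaker inhibition, modestly beyond the scatter.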

Compound 3, half-maximal inhibitory concentration: 85 nM
Estimate against measurement, compound 3: 1.8-fold (0.25 log units) above; the range from low to high includes it.
By their numbers in this assay, from the lowest: compounds 2, 3 and 1 (each within the scatter of the next, the first and the last beyond it).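

In this assay, hydrogen in place of ethyl on a saturated chain carbon bound to two saturated chain carbons gives a 1.3-fold higher number from compound 2 to compound 3 (0.11 log units; within the scatter), so at this position the sec-butyl of compound 2 and the ethyl of compound 3 cannot be told apart. The second single change, benzyl in place of isopropyl on a saturated chain carbon bound to a carbonyl carbon, gives a 1.8-fold lower number from compound 1 to compound 3 (0.25 log units; within the scatter) and also stays within the scatter. Nothing available offers a reason for either result.

The compounds shown leave open whether a phenyl ring, a primary amine or a carboxylic acid in place of the ethyl would move the number beyond the scatter. On these data alone, a longer chain in place of the benzyl remains equally open.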